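Moving a thioether arm on a shared core

The source may report more compounds than this note shows. Statements on the series, on what has been measured and on what is new or still open speak of the compounds shown alone.

Compound 1 `Cc1nnc(SCc2cc(=O)c3ccccc3o2)o1` and compound 3 `Cc1nnc(SCc2coc3ccccc3c2=O)o1` are built from the same atoms joined differently; how the two cores differ is not broken down here. In a functional assay on MDA-MB-435S cells (Homo sapiens) for cytotoxicity, read by MTT assay, with a stated time of 72 h (on this read-out higher numbers stand for weaker inhibition and lower numbers for stronger inhibition), compound 1 gives only the limit > 25000 nM. Compound 2 `Nc1nnc(SCc2cc(=O)c3ccccc3o2)s1` carries the change (5-amino-1,3,4-thiadiazol-2-yl in place of 5-methyl-1,3,4-oxadiazol-2-yl on a sulfur). In this assay compound 2 likewise gives only the limit > 25000 nM. The step that the two limits leave unreadable from compound 1 to compound 2 therefore cannot be sized, as the limit of > 25000 nM in this assay, at which 2 of the 3 values shown sit, shows. Going by the values given here, compound 3 gives 1200 nM in this assay, the only number among the three. Compound 4 `Nc1nnc(SCc2coc3ccccc3c2=O)s1` makes the same change on the core of compound 3, namely (5-amino-1,3,4-thiadiazol-2-yl in place of 5-methyl-1,3,4-oxadiazol-2-yl on a sulfur). The step from compound 3 to compound 4 is expected to be small, a 1.7-fold higher number from compound 3 to compound 4 (0.22 log units; within the scatter), because the step that the two limits leave unreadable from compound 1 to compound 2 gave no readable direction. Compound 4 is estimated at 2000 nM, within 500 nM to 12000 nM.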

Compound 4, half-maximal inhibitory concentration: 950 nM
Compound 4: the middle estimate sits 2.1-fold (0.32 log units) above what was measured; measured number inside the range.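

On the core of compound 3, placing 5-amino-1,3,4-thiadiazol-2-yl on the sulfur instead of 5-methyl-1,3,4-oxadiazol-2-yl gives a 1.3-fold lower number from compound 3 to compound 4 (0.10 log units; within the scatter) in this assay, so the two compounds cannot be told apart in this assay. The same change on the core of compound 1 cannot be read, because compound 1 and compound 2 give only a limit of the assay and not a number: the limit of > 25000 nM in this assay, at which 2 of the 4 values shown sit. This series therefore shows no readable effect of the change on one core, and it does not show whether the change would behave alike on the other.

As far as these compounds go, it remains open whether a different group on the sulfur, such as a carboxylic acid, an amine or a longer chain, would move the number on the core of compound 3.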